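The compounds below may be only part of what the source reports. "The series", "measured", "known", "first", "only" and "open" are said of these compounds alone.

Measured compounds:
Compound 1 `COc1cc(Nc2cc(NC(=O)Nc3c(Cl)cccc3Cl)ncn2)cc(OC)c1`, which in a functional assay on NCI-H1581 cells (Homo sapiens) for inhibition, read by MTT assay, with a stated time of 48 h, tested at 10 uM (on this read-out lower numbers stand for less inhibition and higher numbers for more inhibition at the one concentration tested (going by the name of the read-out)), gives 68%.
Compound 2 `COc1cc(NC(=O)Nc2cc(Nc3cc(C)cc(F)c3)ncn2)cc(OC)c1`, which in this assay gives 28.3%.
Compound 3 `COc1cc(Nc2cc(NC(=O)Nc3c(Cl)cccc3Cl)ncn2)cc(C(F)(F)F)c1`, which in this assay gives 32.3%.

Among these three numbers compound 2 stands lowest. Its nearest neighbour is compound 3, whose value lies within the scatter of it, so no order between the two can be claimed; compound 1 lies furthest away, beyond the scatter. Compound 4 `COc1cc(NC(=O)Nc2cc(Nc3ccc(C(C)(C)C)cc3)ncn2)cc(OC)c1` has not yet been measured. It differs from compound 2 in one place: 4-(tert-butyl)phenyl in place of 3-fluoro-5-methylphenyl on a nitrogen on an aromatic ring.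

Among the compounds with values here, the only measured step concerns a different group on a ring attached to the same kind of nitrogen: a number 35.7 percentage points lower from compound 1 to compound 3 (beyond the scatter), a large fall. Within the data shown here, no measured pair swaps a 3-fluoro-5-methylphenyl for a 4-(tert-butyl)phenyl, so that step offers no direct guide, and the data give no basis for expecting a step beyond the scatter in this assay in either direction. Compound 4 is therefore expected to give about 30%, within a range from 10% to 55%, corresponding to an expected step of a number 1.7 percentage points higher from compound 2 to compound 4 (within the scatter).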

Compound 4, a percentage reported as inhibition, at one concentration (the size of the read-out at that concentration, not a potency): 38.7%
Compound 4: the middle estimate sits 8.7 percentage points below what was measured; measured number inside the range.
By their numbers in this assay, from the lowest: compounds 2, 3 and 4 (each within the scatter of the next, the first and the last beyond it); then compound 1.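

Compound 4 shows that the aryl group on this nitrogen on an aromatic ring can be exchanged with a readable effect in this assay: 4-(tert-butyl)phenyl in place of 3-fluoro-5-methylphenyl goes with a number 10.4 percentage points higher from compound 2 to compound 4 (beyond the scatter), a modest step. Within the data shown here, the only earlier step, a number 35.7 percentage points lower from compound 1 to compound 3 (beyond the scatter), exchanged a single methoxy for a trifluoromethyl and did not replace the whole group on that nitrogen, so this is the first reading for such a replacement here, and the number is higher. No evidence is available that explains this rise.

A single exchange cannot separate the tert-butyl group from the loss of the fluorine or the methyl. Going by these compounds, how a phenyl carrying a morpholine or a carboxylic acid would behave on this nitrogen also remains open.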